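Methoxy added to the benzyl group: expected cell tolerance

A few compounds are considered here, and "the series" means these few. Any claim that something is new, unique, unknown or untested is made for them only; others in the source may bear on it.

Measured so far
Compound 1, `Nc1cc(N)c2nc(-c3ccccc3)c(NCc3ccc(Cl)c(Cl)c3)nc2c1`, in a functional assay on NCI/ADR-RES cells (Homo sapiens) for inhibition, read by sulforhodamine B assay, with a stated time of 48 h; a higher number here means that more compound is tolerated, a lower number that less compound is tolerated: < 100000 nM
Compound 2, `COc1ccc(CNc2nc3cc(N)cc(N)c3nc2-c2ccccc2)cc1OC`, in this assay: < 100000 nM

In this assay compound 1 reports only a limit of the assay, < 100000 nM. Compound 2 likewise reports a limit, < 100000 nM, and not a number. Going by the values given here, the single measured step, a step that the two limits leave unreadable from compound 1 to compound 2, is therefore unreadable in size and direction, since both of its ends sit at the same limit (the limit of < 100000 nM in this assay, at which 2 of the 2 values shown sit). Compound 2 thus stands at a limit alone, with no numerical value to anchor it.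

Compound 3, `COc1cc(CNc2nc3cc(N)cc(N)c3nc2-c2ccccc2)cc(OC)c1OC`, differs from compound 2 by methoxy in place of hydrogen on an aromatic carbon. Among the compounds with values here, no measured step bears directly on this change; the only step available, a step that the two limits leave unreadable from compound 1 to compound 2, concerns a different exchange and is itself unreadable. From the shared limit of the series, compound 3 is expected to remain in the same region, with no step beyond the scatter. Compound 3 is estimated at 30000 nM, with a range from 3000 nM to 100000 nM. This estimate implies an expected step that the limit leaves unreadable from compound 2 to compound 3 against the stated limit, and a real chance that only a limit is again reported.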

Compound 3, concentration lethal to 50% of the cells: 46800 nM
The estimate for compound 3 lay 1.6-fold (0.19 log units) below the measured number; measured number inside the range.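

Compound 3 carries a number, but compound 2 reports only a limit of the assay, so no new step can be read from compound 2 to compound 3 in size or direction: the limit of < 100000 nM in this assay, at which 2 of the 3 values shown sit. The compounds shown leave open whether methoxy in place of hydrogen on an aromatic carbon changes the result in this assay at all.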